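Dimethylamino in place of chloro on the ethoxy analogue

The source may report more compounds than this note shows. Statements on the series, on what has been measured and on what is new or still open speak of the compounds shown alone.

Values in a functional assay on the whole organism (strain Sprague-Dawley) for inhibition, with Rattus norvegicus as the target, with a stated time of 10 min (a lower number here means that less compound is needed, a higher number that more compound is needed for the effect), measured so far
- compound 1 `O=C(O)c1cnc(-c2ccccc2)[nH]c1=O` gives 50 mg/kg
- compound 2 `O=C(O)c1cnc(-c2ccccc2OCc2ccccc2)[nH]c1=O` gives 5 mg/kg
- compound 3 `CCOc1ccc(Cl)cc1-c1ncc(C(=O)O)c(=O)[nH]1` gives 0.5 mg/kg

Compound 3 at 0.5 mg/kg holds the lowest of the three numbers, and its gaps to compound 1 and compound 2 both lie beyond the scatter. The next analogue is compound 4 `CCOc1ccc(N(C)C)cc1-c1ncc(C(=O)O)c(=O)[nH]1` in which dimethylamino stands in place of chloro on an aromatic carbon, para to an ethoxy group, with dimethylamino in place of chloro on an aromatic carbon as the counted difference.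

Within the data shown here, only one measured step changes a single place, namely a 10-fold lower number from compound 1 to compound 2 (1.00 log units; beyond the scatter) for benzyloxy in place of hydrogen on an aromatic carbon. That is a different change, so it shows how far one substituent can move this assay in this small series but gives no direction for compound 4. Among the measured compounds shown here, no measured pair tests chloro or dimethylamino on their own. A step clearly beyond the scatter is therefore not expected, with a slight lean towards a higher number, as the starting point is already the lowest of the three. The estimated step is a 2.0-fold higher number from compound 3 to compound 4 (0.30 log units; within the scatter) with a wide margin either way. For compound 4 the estimated value is 1 mg/kg within an expected range of 0.25 mg/kg to 4 mg/kg in this assay.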

Compound 4, dose for 50% inhibition: 0.3 mg/kg
Beside the measured number, compound 4's estimate is 3.3-fold (0.52 log units) above it; the range from low to high includes it.
By their numbers in this assay, from the lowest: compounds 4 and 3 (each within the scatter of the next); then compound 2; then compound 1.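

In this assay the exchange of chloro for dimethylamino, on an aromatic carbon para to an ethoxy group, gives a 1.7-fold lower number from compound 3 to compound 4 (0.22 log units; within the scatter) and so leaves the two compounds indistinguishable in this whole-animal read-out. This position therefore accepts dimethylamino, with three heavy atoms and one hydrogen-bond acceptor, in place of a single chlorine without a step beyond the scatter. The earlier single-place step, a 10-fold lower number from compound 1 to compound 2 (1.00 log units; beyond the scatter) for benzyloxy in place of hydrogen, concerned a different change and could not show this tolerance, and no measurement at hand bears on why chloro and dimethylamino read alike here.

The compounds shown leave open whether any substituent at this position matters in this assay at all, as no pair sets hydrogen, a primary amine or a carboxylic acid there against chloro or dimethylamino. On these data alone, the part played by the ethoxy group also stays open, and a pair in which a longer chain such as butoxy replaces it, with the group at this position held constant, would address that.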